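Aryl variation on the shared core of compound 1

The compounds below may be only part of what the source reports. "The series", "measured", "known", "first", "only" and "open" are said of these compounds alone.

Compound 3 `CC(=O)c1ccc(-c2cn3ccnc3c(-c3ccc4ncn(C5CCCCC5)c4c3)n2)cc1` stands lowest of the three measured compounds: in a functional assay on K562 cells (Homo sapiens) for inhibition, read by sulforhodamine B assay, with a stated time of 48 h, tested at 10 uM (a lower number here means less inhibition, a higher number more inhibition at the concentration tested (going by the name of the read-out)), compound 3 gives 9.6%, whereas compound 1 `c1ccc(-c2cn3ccnc3c(-c3ccc4ncn(C5CCCCC5)c4c3)n2)cc1` gives 70.6% and compound 2 `c1cn2cc(-c3ccsc3)nc(-c3ccc4ncn(C5CCCCC5)c4c3)c2n1` gives 22%. Compound 4 `COc1ccccc1-c1cn2ccnc2c(-c2ccc3ncn(C4CCCCC4)c3c2)n1` has not yet been measured; its change from compound 3 is 2-methoxyphenyl in place of 4-acetylphenyl on an aromatic carbon. Among the measured compounds shown here, two measured steps bear on this change. The acetyl enters in a number 61 percentage points lower from compound 1 to compound 3 (beyond the scatter), and the 4-acetylphenyl replaces thiophen-3-yl in a number 12.4 percentage points lower from compound 2 to compound 3 (beyond the scatter). Both steps run downward, and compound 4 undoes the group that carried them, so the expectation is a return toward the value of compound 1. For the measured compounds named here, the 2-methoxyphenyl that enters has no precedent among the measured compounds, so the range kept for compound 4 is wide. For compound 4 the value expected in this assay is 50%, with a range from 20% to 75%, which means an expected rise of a number 40.4 percentage points higher from compound 3 to compound 4 (beyond the scatter).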

Compound 4, a percentage reported as inhibition, at one concentration (the size of the read-out at that concentration, not a potency): 22.6%
Beside the measured number, compound 4's estimate is 27.4 percentage points above it; the measured number falls inside the stated range.
By their numbers in this assay, from the lowest: compound 3; then compounds 2 and 4 (each within the scatter of the next); then compound 1.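

In this assay, exchanging the 4-acetylphenyl for 2-methoxyphenyl gives only a partial recovery, a number 13 percentage points higher from compound 3 to compound 4 (beyond the scatter), while methoxy in place of hydrogen on the phenyl of compound 1 still means a number 48 percentage points lower from compound 1 to compound 4 (beyond the scatter), so the loss at this position is not confined to the acetyl. The 2-methoxyphenyl and thiophen-3-yl groups cannot be told apart here, with a number 0.6 percentage points higher from compound 2 to compound 4 (within the scatter), and among the four compounds only the unsubstituted phenyl of compound 1 stands well clear of the others. Nothing measured on hand accounts for these steps.

Open, as far as these compounds go, is whether any substituent on that phenyl keeps the number of compound 1, for instance a fluorine, an amine or a carboxylic acid in place of hydrogen. Also open, from the compounds shown here alone, is whether the place of the substituent or its identity matters more, since methoxy and acetyl differ in both between compound 3 and compound 4.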